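Series notes: dimethylamino to 2-methylpyrrolidin-1-yl on the shared core

This account rests on a few compounds, and the source may have more. Where it says the series, first, only, none or still open, it means among the compounds named here.

Measured so far:
compound 1 `C[C@@H]1CCCN1c1c(C#N)c2c(N)nc(Nc3ccn(C)n3)cc2n1C` 234 nM
compound 2 `CN(C)c1c(C#N)c2c(N)ncnc2n1C` 4620 nM

In an assay on isolated protein for inhibition of Leucine-rich repeat serine/threonine-protein kinase 2 (Homo sapiens), read by TR-FRET and LanthaScreen, with stated times of 50 min and 30 min, in the presence of a further agent that is not named here (on this read-out higher numbers stand for weaker inhibition and lower numbers for stronger inhibition), compound 2 gives the highest of the two numbers; compound 1 sits at a lower number, and the gap between them is beyond the scatter of the method. Among the compounds with values here, compound 1 shares the 2-methylpyrrolidin-1-yl group with compound 3 but differs from it elsewhere as well, so no single step links it to either of the other compounds and its value serves only as a point of reference.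

Compound 3 `C[C@@H]1CCCN1c1c(C#N)c2c(N)ncnc2n1C` is not yet measured. Relative to compound 2 it carries the change (2-methylpyrrolidin-1-yl in place of dimethylamino on an aromatic carbon).

Within the data shown here, no measured pair isolates this change, so the size of the step is uncertain. Given that compound 1, which bears the entering group, shows 234 nM while compound 2 shows 4620 nM, a move toward a lower number is expected for compound 3, though of moderate size and possibly within the scatter. The expected step is a 3.1-fold lower number from compound 2 to compound 3 (0.49 log units; beyond the scatter). For compound 3 the estimate in this assay is 1500 nM, with a range from 400 nM to 5000 nM.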

Compound 3, half-maximal inhibitory concentration: 15 nM
Compound 3: the middle estimate sits 100-fold (2.00 log units) above what was measured; the whole stated range lies above it.
By their numbers in this assay, from the lowest: compound 3; then compound 1; then compound 2.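

In this assay the exchange of dimethylamino for 2-methylpyrrolidin-1-yl on this aromatic carbon gives a 310-fold lower number from compound 2 to compound 3 (2.49 log units; beyond the scatter) and shows that this single place on the shared core can carry a large change in the read-out. The earlier compounds shown here differed in more than one place and could not assign any of their gap to this group, whereas here the rest of the structure stays the same and compound 3 at 15 nM also prints a lower number than compound 1 at 234 nM without the additional substitution found on compound 1. Nothing shown gives a reason for the size of this step.

The entering group adds a ring, a methyl group and a defined stereocentre at once, so the compounds shown do not tell which of these features accounts for the step. Going by these compounds, an unsubstituted pyrrolidin-1-yl, a piperidin-1-yl or the opposite stereoisomer of the 2-methylpyrrolidin-1-yl group would each separate part of this question, and the effect of the same exchange on other forms of the core also remains open.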